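The source may report more compounds than this note shows. Statements on the series, on what has been measured and on what is new or still open speak of the compounds shown alone.

Compound 1 `O=C(/N=C/c1ccc([N+](=O)[O-])cc1)Nc1ccc2c(c1)C(=O)C(=O)N2CN1CCCCC1` in a functional assay on the whole organism (strain Swiss albino) with Mus musculus as the target, with a stated time of 0.5 h (a lower number here means that less compound is needed, a higher number that more compound is needed for the effect), gives 300 mg/kg.
Compound 2 `COc1ccc(/C=N/C(=O)Nc2ccc3c(c2)C(=O)C(=O)N3CN2CCCCC2)cc1` in this assay gives 300 mg/kg.

Compound 2 stands at the same value as compound 1 at the digits shown; the step of no change at the digits printed from compound 1 to compound 2 (within the scatter) stayed within the scatter, although it exchanged one group for another on the aromatic ring. The move to compound 3 `Cc1ccc(/C=N/C(=O)Nc2ccc3c(c2)C(=O)C(=O)N3CN2CCCCC2)cc1` is a change at that same spot, (methyl in place of methoxy on an aromatic carbon), leaving everything else untouched. Within the data shown here, only one measured step bears on it, and that step, from compound 1 to compound 2, produced no change at this ring position; there is no measurement of a methyl group here, so the expectation rests on that single comparison. A step of no more than the scatter is expected. Compound 3 is therefore estimated to give 300 mg/kg, with a range of 150 mg/kg to 600 mg/kg. That estimate corresponds to an expected step of no change at the digits printed from compound 2 to compound 3 (within the scatter).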

Compound 3, minimum effective dose: 300 mg/kg
Beside the measured number, compound 3's estimate shows no gap at the digits printed; measured number inside the range.
By their numbers in this assay, from the lowest: compounds 1, 2 and 3 (each within the scatter of the next).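

In this assay, putting methyl in place of methoxy gives no change at the digits printed from compound 2 to compound 3 (within the scatter) and putting methyl in place of nitro gives no change at the digits printed from compound 1 to compound 3 (within the scatter) on the same aromatic carbon, para to a large group. A second comparison at this position had been lacking, and the read-out now stays level across three different groups there: nitro, methoxy and methyl. Nothing measured here offers an explanation for this sameness.

The compounds shown leave open whether an amine, a carboxylic acid or a longer chain such as butyl at this position would also stay level with these three. They also cannot say whether the same holds for a group placed elsewhere on this ring, or for changes to the shared core, which is identical in all three compounds.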